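The source may report more compounds than this note shows. Statements on the series, on what has been measured and on what is new or still open speak of the compounds shown alone.

Compound 3 `Oc1nc(NCc2ccccc2)nc2ccc(I)cc12` gives 106% in a functional assay on the whole organism (uterus) with Rattus norvegicus as the target, tested at 10 uM (a higher number here means a weaker effect of the compound at the concentration tested, a lower number a stronger effect), and stands as the highest of the three numbers, though the gap to compound 2 is within the scatter. Compound 2 `Oc1nc(NCC2CCCCC2)nc2ccc(I)cc12` gives 96.8% in this assay, and compound 1 `Oc1nc(NCc2ccccc2)nc2ccc(Cl)cc12` gives 94.8%, beyond the scatter from compound 3. Compound 4 `Oc1nc(NCc2ccccc2)nc2ccc(Br)cc12` differs from compound 3 by bromo in place of iodo on an aromatic carbon. The step that bears on this is the change of the same halogen, a number 11.2 percentage points higher from compound 1 to compound 3 (beyond the scatter); the step of a number 9.2 percentage points higher from compound 2 to compound 3 (within the scatter) touches another part and is less relevant. With bromo standing between chloro and iodo, a small decrease is expected, a number 6 percentage points lower from compound 3 to compound 4 (within the scatter), possibly within the scatter. Compound 4 is estimated at 100%, range 88% to 112%.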

Compound 4, a percentage reported as activity, at one concentration (the size of the read-out at that concentration, not a potency): 76.8%
Compound 4: middle estimate off by 23.2 percentage points, on the high side; the measured number lies below the stated range.
By their numbers in this assay, from the lowest: compound 4; then compounds 1, 2 and 3 (each within the scatter of the next, the first and the last beyond it).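

In this assay, bromo on this aromatic carbon gives a number 29.2 percentage points lower from compound 3 to compound 4 (beyond the scatter) and a number 18 percentage points lower from compound 1 to compound 4 (beyond the scatter), placing it outside the span set by chloro and iodo rather than inside it. Going by these compounds alone, the single chloro-to-iodo step had suggested a direction, but the three halogens together follow no steady order along chloro, bromo, iodo. Nothing available explains why bromo differs from the other two halogens.

Still open, on these data alone, is whether fluoro, methoxy or an amine on this carbon would give a number as low as bromo does. Also open, as far as these compounds go, is whether bromo keeps this place with cyclohexyl in place of phenyl on the side chain.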